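Aryl group variation at the five-membered ring

The source may hold more compounds than are shown below. What is called first, only, known or untested is meant among the compounds shown, and "the series" means these compounds.

Compound 3 `Cc1nc(-c2ccccc2F)sc1COc1ccc2c(c1)OCC2CC(=O)O` gives 25.8% in a functional assay on CHO cells for agonist activity at Free fatty acid receptor 1 (Homo sapiens), read by FLIPR and calcium flux, tested at 100 nM; on this read-out higher numbers stand for a stronger effect at the one concentration tested and lower numbers for a weaker effect. It lies within the scatter of compound 1 `Cc1nc(-c2cccs2)sc1COc1ccc2c(c1)OCC2CC(=O)O`, which gives 35.2%. Compound 2 `Cc1ccccc1-c1nc(C)c(COc2ccc3c(c2)OCC3CC(=O)O)s1` gives 10.7%, and compound 3 stands higher than compound 2 by more than the scatter. The step to compound 4 `COc1cc(OC)cc(-c2nc(C)c(COc3ccc4c(c3)OCC4CC(=O)O)s2)c1` is 3,5-dimethoxyphenyl in place of 2-fluorophenyl on an aromatic carbon. The measured steps that bear on it all alter the same aryl group: a number 9.4 percentage points lower from compound 1 to compound 3 (within the scatter), a number 15.1 percentage points higher from compound 2 to compound 3 (beyond the scatter) and a number 24.5 percentage points lower from compound 1 to compound 2 (beyond the scatter). For the measured compounds named here, they show that this group matters, compound 2 being the weakest of the three, but no measured step introduces two methoxy groups, so the direction is open. A modest downward step is expected: a number 5.8 percentage points lower from compound 3 to compound 4 (within the scatter). Compound 4 is estimated at 20%, with a range from 5% to 42%.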

Compound 4, a percentage reported as activity, at one concentration (the size of the read-out at that concentration, not a potency): 17.5%
Beside the measured number, compound 4's estimate is 2.5 percentage points above it; measured number inside the range.
By their numbers in this assay, from the lowest: compounds 2, 4, 3 and 1 (each within the scatter of the next, the first and the last beyond it).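

In this assay the 3,5-dimethoxyphenyl group cannot be told apart from either ortho-free comparison

In this assay the 3,5-dimethoxyphenyl group cannot be told apart from 2-fluorophenyl, with a number 8.3 percentage points lower from compound 3 to compound 4 (within the scatter), or from 2-methylphenyl, with a number 6.8 percentage points higher from compound 2 to compound 4 (within the scatter). Thiophen-2-yl does stand apart from it, with a number 17.7 percentage points lower from compound 1 to compound 4 (beyond the scatter), so the two methoxy groups and their hydrogen-bond acceptors bring no gain at this position. Nothing available explains these differences. From the compounds shown here alone, whether a pyridine ring or a furan ring in place of the thiophene would match or pass compound 1 stays open. So does the effect of a single methoxy group on the phenyl ring.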